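Swapping a Sulfonyl for a Carbonyl on the Acrylonitrile Arm

This account rests on a few compounds, and the source may have more. Where it says the series, first, only, none or still open, it means among the compounds named here.

Compound 1 `COc1ccc(-c2[nH]c3ccccc3c2/C=C(\C#N)S(=O)(=O)c2ccccc2)cc1`: 428 nM
Compound 2 `N#C/C(=C\c1c(-c2ccccc2)[nH]c2ccccc12)S(=O)(=O)c1ccccc1`: 1100 nM

Among the compounds with values here, in a functional assay on NCI/ADR-RES cells (Homo sapiens) for inhibition, read by sulforhodamine B assay, with a stated time of 48 h (a higher number here means a weaker inhibitor of growth, a lower number a stronger inhibitor of growth), compound 2 gives 1100 nM, the highest of the two numbers seen so far, and the single measured step, a 2.6-fold higher number from compound 1 to compound 2 (0.41 log units; beyond the scatter), arose from removing a methoxy group from the aromatic ring attached to the shared core. That step tells nothing about the part of the molecule now being altered.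

Compound 3 `N#C/C(=C\c1c(-c2ccccc2)[nH]c2ccccc12)C(=O)c1ccccc1` keeps the whole core of compound 2 and changes only one thing: benzoyl in place of phenylsulfonyl on a double-bonded chain carbon bound to a double-bonded chain carbon and a triple-bonded carbon. No measured step among the compounds shown involves this position or this exchange, so there is no directly relevant precedent; the direction and size of the step in this assay cannot be anchored to a measured comparison.

With nothing to lean on, the expectation is that compound 3 lands near compound 2, with a broad range, and the estimated value for compound 3 is 1500 nM (range 400 nM to 6000 nM), meaning an expected step of a 1.4-fold higher number from compound 2 to compound 3 (0.13 log units; within the scatter).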

Compound 3, concentration for 50% growth inhibition: 3100 nM
Estimate against measurement, compound 3: 2.1-fold (0.32 log units) below; the range from low to high includes it.
By their numbers in this assay, from the lowest: compound 1; then compound 2; then compound 3.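

In this assay, benzoyl in place of phenylsulfonyl on a double-bonded chain carbon bound to a double-bonded chain carbon and a triple-bonded carbon gives a 2.8-fold higher number from compound 2 to compound 3 (0.45 log units; beyond the scatter) and so shows that the number responds to what this carbon carries, with phenylsulfonyl the stronger inhibitor of growth in this one pair. The exchange is a small one on paper: the six-membered aromatic ring stays, and the count goes from 9 heavy atoms and 2 hydrogen-bond acceptors in phenylsulfonyl to 8 heavy atoms and 1 hydrogen-bond acceptor in benzoyl. No measurement at hand accounts for this step, so the reason for it remains unknown.

The compounds shown leave open whether the aromatic ring on this arm is needed at all, which a carboxylic acid, an amide or a methylsulfonyl group at the same carbon could test. They also leave open whether the methoxy group on the aromatic ring would change the number in the same direction when benzoyl is present, as only the phenylsulfonyl pair gives that reading.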